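A Bromo for Chloro Swap on Compound 1

A few compounds are considered here, and "the series" means these few. Any claim that something is new, unique, unknown or untested is made for them only; others in the source may bear on it.

Going by the values given here, in a functional assay (aorta) with Rattus norvegicus as the target (a higher number here means that more compound is needed for the effect, a lower number that less compound is needed), compound 1 (`CCNC1=NS(=O)(=O)c2cc(Cl)ccc2N1`) gives 39.9 uM, the lower of the two numbers available so far. Among the compounds with values here, the only other measured compound, compound 2 (`CCC(CC)NC1=NS(=O)(=O)c2cc(Cl)ccc2N1`), gives 93.6 uM.

The next compound to be tested is compound 3 (`CCNC1=NS(=O)(=O)c2cc(Br)ccc2N1`), which keeps the ethyl group on the amine nitrogen of compound 1. Within the data shown here, its single change is bromo in place of chloro on an aromatic carbon.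

Among the measured compounds shown here, the one measured step, a 2.3-fold higher number from compound 1 to compound 2 (0.37 log units; beyond the scatter), is modest but beyond the scatter. It concerns the group on the amine nitrogen, however, and not the aromatic carbon, so it bears on the new change only indirectly. For the measured compounds named here, no measured step shows what a change of halogen does here, and the direction remains open. The expectation in this assay is therefore no step beyond the scatter, and it stays anchored on compound 1 at 39.9 uM.

For compound 3 the expected value is 38 uM, with an estimated range from 16 uM to 90 uM. This estimate corresponds to an expected 1.1-fold lower number from compound 1 to compound 3 (0.02 log units; within the scatter).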

Compound 3, concentration for half-maximal effect: 6.2 uM
Beside the measured number, compound 3's estimate is 6.1-fold (0.79 log units) above it; measured number outside the range, below it.
By their numbers in this assay, from the lowest: compound 3; then compound 1; then compound 2.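

The swap of one halogen for another on this aromatic carbon, with the ethyl group on the amine nitrogen held fixed, gives the first view of this position in this assay, and it shows that the position responds: the change produces a 6.4-fold lower number from compound 1 to compound 3 (0.81 log units; beyond the scatter). Going by these compounds alone, until now the only change on the core of compound 1 was on the amine nitrogen, where the number moved the other way, with a 2.3-fold higher number from compound 1 to compound 2 (0.37 log units; beyond the scatter), so the two places on the molecule can shift the read-out in opposite directions. No supporting measurement bears on why bromo acts in this way at this position.

Open, as far as these compounds go, is whether the trend runs on with the other halogens, iodo and fluoro, or whether a non-halogen group such as methyl or trifluoromethyl on the same aromatic carbon would give a similar number. Also open, from the compounds shown here alone, is whether bromo keeps this step when the ethyl group gives way to pentan-3-yl on the amine nitrogen, which would show whether the two changes act independently of each other.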